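Replacing the cyanophenyl group on compound 3

This account rests on a few compounds, and the source may have more. Where it says the series, first, only, none or still open, it means among the compounds named here.

Compound 3 `C[C@H](Nc1ncnc2[nH]cnc12)c1nn(-c2ccc(C#N)cc2)c2cc(F)ccc12` gives 57% in a functional assay on HepG2 cells (Homo sapiens) for inhibition, read by sulforhodamine B assay, with a stated time of 72 h, tested at 10 uM (a lower number here means less inhibition, a higher number more inhibition at the concentration tested (going by the name of the read-out)), the highest of the three numbers measured. Compound 2 `C[C@H](Nc1ncnc2[nH]cnc12)c1nn(-c2cccnc2)c2cc(F)ccc12` gives 23%, and compound 1 `C[C@H](Nc1ncnc2[nH]cnc12)c1nn(-c2cccnc2)c2ccc(F)cc12` gives 8%; both lie beyond the scatter below compound 3. Going by the values given here, the one measured step that bears on the change at hand is a number 34 percentage points higher from compound 2 to compound 3 (beyond the scatter), a large rise. Compound 4 `C[C@H](Nc1ncnc2[nH]cnc12)c1nn(-c2cc(F)cc(F)c2)c2cc(F)ccc12` differs from compound 3 by 3,5-difluorophenyl in place of 4-cyanophenyl on an aromatic nitrogen. The group on the aromatic nitrogen is altered again, the same place whose change produced that large rise, so a step beyond the scatter is plausible, though a single step cannot fix its direction. Compound 4 is therefore expected to give 35%, with a range of 12% to 60%, which means an expected step of a number 22 percentage points lower from compound 3 to compound 4 (beyond the scatter).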

Compound 4, a percentage reported as inhibition, at one concentration (the size of the read-out at that concentration, not a potency): 30%
Compound 4: the middle estimate sits 5 percentage points above what was measured; the range from low to high includes it.
By their numbers in this assay, from the lowest: compound 1; then compounds 2 and 4 (each within the scatter of the next); then compound 3.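

In this assay the 4-cyanophenyl group cannot be exchanged for 3,5-difluorophenyl on this aromatic nitrogen without loss, with a number 27 percentage points lower from compound 3 to compound 4 (beyond the scatter) as the modest drop. The earlier rise therefore does not come with every six-membered aromatic ring of carbon only. The result for 3,5-difluorophenyl in place of pyridin-3-yl is a number 7 percentage points higher from compound 2 to compound 4 (within the scatter) and does not separate those two groups. From the compounds shown here alone, whether an amide or a carboxylic acid in place of the nitrile would keep the inhibition of compound 3 stays open. Nothing available here accounts for these differences between the groups.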